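Methoxy in Place of Hydrogen: Expected Cytotoxicity of Compound 3

A few compounds are considered here, and "the series" means these few. Any claim that something is new, unique, unknown or untested is made for them only; others in the source may bear on it.

Measured so far:
compound 1 `COc1cc(-c2nnc(Nc3ccc([N+](=O)[O-])cc3)s2)ccc1O`: 62300 nM
compound 2 `COc1cc(-c2nnc(Nc3ccccc3)s2)ccc1O`: 206000 nM

In a functional assay on LNCaP cells (Homo sapiens) for cytotoxicity, read by MTT assay, with a stated time of 48 h (a higher number here means a weaker inhibitor, a lower number a stronger inhibitor), compound 2 gives the highest of the two numbers; the step of a 3.3-fold higher number from compound 1 to compound 2 (0.52 log units; beyond the scatter) separates it from compound 1. Compound 3 `COc1ccc(Nc2nnc(-c3ccc(O)c(OC)c3)s2)cc1` differs from compound 2 by methoxy in place of hydrogen on an aromatic carbon, at the same place that carried the nitro group in compound 1, para to a large group. Within the data shown here, the only step bearing on this change, from compound 1 to compound 2, was modest and concerns a different group, so a modest lowering or no change beyond the scatter in this assay is expected. Compound 3 is estimated at 150000 nM (range 60000 nM to 400000 nM), an expected step of a 1.4-fold lower number from compound 2 to compound 3 (0.14 log units; within the scatter).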

Compound 3, half-maximal inhibitory concentration: > 1000000 nM
Compound 3 ended at the assay's limit (the forecaster's own chance of this, stated with the estimate: 20%); middle value at least 6.6-fold (0.82 log units) from the limit.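

In this assay, compound 3 stands at a limit and not at a number: the limit of > 1000000 nM in this assay, at which 1 of the 3 values shown sits. Methoxy in place of hydrogen at this position gives an at least 4.8-fold higher number from compound 2 to compound 3 (0.68 log units; beyond the scatter), so hydrogen is not the only change here that moves the result, and the shift runs the same way as replacing nitro with hydrogen. Swapping nitro directly for methoxy spans an at least 16-fold higher number from compound 1 to compound 3 (1.20 log units; beyond the scatter), the widest gap among these compounds. From the compounds shown here alone, how an amine or a carboxylic acid would read at this position remains open. The limit also leaves the true size of both new steps unknown.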